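The compounds below may be only part of what the source reports. "The series", "measured", "known", "first", "only" and "open" are said of these compounds alone.

Series notes, shared core with a varied aryl group on the amide-bearing benzamide.

Compound 1 `CNC(=O)N1CCCc2ccc(NC(=O)c3ccc(-c4ccncc4)cc3)cc21` gives 37.6% in a functional assay on MV4-11 cells (Homo sapiens) for antiproliferative activity, with a stated time of 6 days, tested at 1.56 uM; on this read-out higher numbers stand for a stronger effect at the one concentration tested and lower numbers for a weaker effect. Among the three measured compounds it stands second highest: compound 2 `CNC(=O)N1CCCc2ccc(NC(=O)c3cccc(-c4cnn(S(C)(=O)=O)c4)c3)cc21` lies lower at 1.6%, and compound 3 `CNC(=O)N1CCCc2ccc(NC(=O)c3ccc(-c4cc[nH]n4)cc3)cc21` lies higher at 92.5%, both gaps beyond the scatter. Going by the values given here, compound 2 differs from compound 1 in more than one place, so only its value is noted; no single step connects the two.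

Compound 4 `CNC(=O)N1CCCc2ccc(NC(=O)c3ccc(-c4cnn(C)c4)cc3)cc21` is not yet measured. It differs from compound 1 as follows: 1-methyl-1H-pyrazol-4-yl in place of pyridin-4-yl on an aromatic carbon.

Among the compounds with values here, the one measured step that bears on this change is the exchange at the same place in compound 1 leading to compound 3, a number 54.9 percentage points higher from compound 1 to compound 3 (beyond the scatter). That replacement put a 1H-pyrazol-3-yl with one hydrogen-bond donor in place of the pyridin-4-yl; the 1-methyl-1H-pyrazol-4-yl entering compound 4 brings two acceptors and no donor, and the pyrazole is joined through a different ring atom. The step in compound 3 shows that a five-membered ring at this position can move the number upward by a large amount; the expectation for compound 4 is a smaller rise, a number 14.4 percentage points higher from compound 1 to compound 4 (beyond the scatter), with the possibility of no change beyond the scatter.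

Compound 4 is therefore estimated at 52%, within a range of 20% to 85%.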

Compound 4, a percentage reported as inhibition, at one concentration (the size of the read-out at that concentration, not a potency): 77.4%
The estimate for compound 4 lay 25.4 percentage points below the measured number, and the stated range covers the measured number.
By their numbers in this assay, from the lowest: compound 2; then compound 1; then compound 4; then compound 3.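

In this assay, the rise from pyridin-4-yl is not limited to a single replacement: 1-methyl-1H-pyrazol-4-yl also gives a number 39.8 percentage points higher from compound 1 to compound 4 (beyond the scatter) and does so with 0 hydrogen-bond donors, so among compounds 1, 3 and 4 a hydrogen-bond donor on the five-membered aromatic ring is not required for a large upward step at this place. The two pyrazoles are not equal, with a number 15.1 percentage points lower from compound 3 to compound 4 (beyond the scatter) as the printed difference, yet this single exchange alters the attachment through the ring, the methyl group and the hydrogen-bond donor count together, and these contributions cannot be separated here. No measured evidence on hand gives a reason for either step.

Still open, as far as these compounds go, is how much of the gap between compound 3 and compound 4 belongs to the methyl group and how much to the ring atom carrying the attachment, which a 1-methyl-1H-pyrazol-3-yl or an unsubstituted 1H-pyrazol-4-yl at the same place would address. Also open, from the compounds shown here alone, is whether the number holds when the methyl group on the pyrazole gives way to a longer chain, an amine or a carboxylic acid.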